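The source may report more compounds than this note shows. Statements on the series, on what has been measured and on what is new or still open speak of the compounds shown alone.

The study covers four compounds examined, or still to be examined, in a functional assay on KB cells (Homo sapiens) for cytotoxicity, read by MTT assay, with a stated time of 48 h; on this read-out lower numbers stand for stronger inhibition and higher numbers for weaker inhibition. Compound 1, `CCn1cc(-c2nc3ccccc3o2)c(=O)c2cc(F)c(Cl)cc21`, gives 10200 nM in this assay. Compound 2, `CCn1cc(-c2nc3ccccc3o2)c(=O)c2cc(F)c(N3CCNCC3)nc21`, is built on a different core; the difference between the two cores is not broken down here, and in this assay compound 2 gives 11700 nM, a number within the scatter of compound 1. Compound 3, `CCn1cc(-c2nc3ccc([N+](=O)[O-])cc3o2)c(=O)c2cc(F)c(Cl)cc21`, carries the change (nitro in place of hydrogen on an aromatic carbon); in this assay compound 3 gives 500 nM, and the step of a 20-fold lower number from compound 1 to compound 3 (1.31 log units; beyond the scatter) is the one large movement among the three measured compounds.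

Compound 4, `CCn1cc(-c2nc3ccc([N+](=O)[O-])cc3o2)c(=O)c2cc(F)c(N3CCNCC3)nc21`, has not yet been measured. It stands to compound 2 as compound 3 stands to compound 1, through the change (nitro in place of hydrogen on an aromatic carbon). The two descriptions of the place agree word for word, so this is the same change, now made on the core of compound 2. It occurs twice among the compounds shown, once measured and once not. With a single measured example, the expectation for compound 4 rests on that one step and on the near-identical starting points of compound 1 and compound 2 in this assay. Compound 4 is therefore expected to show a step of about a 15-fold lower number from compound 2 to compound 4 (1.17 log units; beyond the scatter). The expectation is held a little short of the precedent a 20-fold lower number from compound 1 to compound 3 (1.31 log units; beyond the scatter), as the two cores differ in more than one place. Compound 4 is estimated at 800 nM in this assay, with a range from 300 nM to 2500 nM.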

Compound 4, half-maximal inhibitory concentration: 1800 nM
For compound 4 the middle estimate is 2.3-fold (0.35 log units) below the measured one, within the range that was stated.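

In this assay nitro in place of hydrogen on an aromatic carbon again gives a lower number on the core of compound 2, with a 6.5-fold lower number from compound 2 to compound 4 (0.81 log units; beyond the scatter), so in these two pairs the direction of the change carries from one core to the other. The size of the step does not carry over in full, since the step on the core of compound 2 is the smaller of the two and the gap between them lies beyond the scatter: the same change on two cores in this assay, a 20-fold lower number (1.31 log units; beyond the scatter) from compound 1 to compound 3 and a 6.5-fold lower number (0.81 log units; beyond the scatter) from compound 2 to compound 4, 3.1-fold (0.50 log units) apart, beyond the scatter of two such steps. Within the data shown here, with only one pair on each core, and with cores that differ in more than one place, these data do not show which of those differences goes with the smaller step, nor how the change would behave on any further core.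

The compounds shown leave open whether another group in the same place, such as an amine, a nitrile or a trifluoromethyl, would lower the number as nitro does and whether it would also do so to different extents on the two cores. From the compounds shown here alone, all four compounds also carry the same ethyl chain, so the effect of a longer chain there on either core remains open as well.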